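Swapping the aryl group on the core's saturated ring carbon

This account rests on a few compounds, and the source may have more. Where it says the series, first, only, none or still open, it means among the compounds named here.

Compound 1 `COC(=O)C1=C(C)N=C(C)/C(=C(\O)OC)C1c1c(Cl)cccc1Cl` is measured in a functional assay (muscle tissue) with Cavia porcellus as the target (a higher number here means that more compound is needed for the effect, a lower number that less compound is needed), where compound 1 gives 1.91 nM, the lowest number of the three measured. Compound 2 `COC(=O)C1=C(C)N=C(C)/C(=C(\O)OC)C1c1ccc(F)cc1` gives 129 nM and compound 3 `COC(=O)C1=C(C)N=C(C)/C(=C(\O)OC)C1c1cccc(C#N)c1` gives 34.7 nM, with a 68-fold higher number from compound 1 to compound 2 (1.83 log units; beyond the scatter) and an 18-fold higher number from compound 1 to compound 3 (1.26 log units; beyond the scatter), and a 3.7-fold lower number from compound 2 to compound 3 (0.57 log units; beyond the scatter). Compound 4 `COC(=O)C1=C(C)N=C(C)/C(=C(\O)OC)C1c1ccc(Br)cc1` differs from compound 1 by 4-bromophenyl in place of 2,6-dichlorophenyl on a saturated ring carbon. For the measured compounds named here, the step that bears most directly on this change is the one to compound 2, where another single substituent at the same ring position in place of 2,6-dichlorophenyl gave a large rise; the step to compound 3 points the same way. A large rise in this assay is therefore expected for compound 4, estimated as a 42-fold higher number from compound 1 to compound 4 (1.62 log units; beyond the scatter). Compound 4 is expected to give about 80 nM, within 20 nM to 320 nM.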

Compound 4, half-maximal effective concentration: 540 nM
Beside the measured number, compound 4's estimate is 6.8-fold (0.83 log units) below it; measured number outside the range, above it.
By their numbers in this assay, from the lowest: compound 1; then compound 3; then compound 2; then compound 4.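

In this assay the change to 4-bromophenyl gives a 280-fold higher number from compound 1 to compound 4 (2.45 log units; beyond the scatter) and is the largest step yet away from 2,6-dichlorophenyl. It also gives a 16-fold higher number from compound 3 to compound 4 (1.19 log units; beyond the scatter) and so stands apart from the nitrile-bearing ring. Exchanging one halogen on an aromatic carbon, bromo in place of fluoro, gives a 4.2-fold higher number from compound 2 to compound 4 (0.62 log units; beyond the scatter) and shows that the single substituent's identity matters, not only the departure of 2,6-dichlorophenyl.

No measurement here explains these differences. As far as these compounds go, how a phenyl ring bearing an amine or a carboxylic acid would behave at this ring carbon remains open.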